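Swapping the dichlorophenyl for a methylphenyl in a phenoxy acid

The source may report more compounds than this note shows. Statements on the series, on what has been measured and on what is new or still open speak of the compounds shown alone.

Compound 1 `O=C(O)C[C@@H]1CCCN1c1ccc(OCc2ccc(Cl)cc2Cl)cc1` gives 340 nM in a functional assay on cells for agonist activity at Free fatty acid receptor 1 (Homo sapiens), read by FLIPR and calcium flux, with a stated time of 100 s (a lower number here means that less compound is needed, a higher number that more compound is needed for the effect), the lower of the two numbers measured. Compound 2 `O=C(O)C[C@H]1CCCN1c1ccc(OCc2ccc(Cl)cc2Cl)cc1` gives 880 nM, and the step of a 2.6-fold higher number from compound 1 to compound 2 (0.41 log units; beyond the scatter) rests on (the fact that compounds 1 and 2 differ only in the configuration as drawn). Compound 3 `Cc1ccccc1COc1ccc(N2CCC[C@H]2CC(=O)O)cc1` changes something else: 2-methylphenyl in place of 2,4-dichlorophenyl on a saturated chain carbon bound to an oxygen on an aromatic ring. Among the measured compounds shown here, no measured step bears on such a swap of the aromatic group, so the step from compound 1 to compound 3 has no direct precedent here. Compound 3 is nonetheless expected to need somewhat more material, with an estimated 3.2-fold higher number from compound 1 to compound 3 (0.51 log units; beyond the scatter), giving an estimate of 1100 nM for compound 3, within a range of 300 nM to 4500 nM.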

Compound 3, half-maximal effective concentration: 190 nM
The estimate for compound 3 lay 5.8-fold (0.76 log units) above the measured number; the whole stated range lies above it.
By their numbers in this assay, from the lowest: compounds 3 and 1 (each within the scatter of the next); then compound 2.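

Putting 2-methylphenyl in place of 2,4-dichlorophenyl gives a 1.8-fold lower number from compound 1 to compound 3 (0.25 log units; within the scatter) in this assay, so the two compounds cannot be told apart. On this pair, then, the ring at this position keeps its reading without either chlorine, something the earlier pair, which differs only in configuration, could not show. Nothing at hand explains why the two groups read alike.

Still open is whether this ring needs any substituent at all, since plain phenyl is not among the compounds shown. How a 2-methoxyphenyl or a pyridine ring would read here is open too.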